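A few compounds are considered here, and "the series" means these few. Any claim that something is new, unique, unknown or untested is made for them only; others in the source may bear on it.

Measured so far: compound 1 `Cc1ccc(S(=O)(=O)Nc2cccc(-c3ccc(C(=O)c4cc(F)c(F)c(O)c4F)s3)c2)cc1`, 9.9 nM in an assay on liver for inhibition of estradiol 17-beta-dehydrogenase 2 (Mus musculus), read by HPLC, in the presence of a further agent that is not named here; on this read-out higher numbers stand for weaker inhibition and lower numbers for stronger inhibition; compound 2 `O=C(c1ccc(-c2cccc(NS(=O)(=O)c3ccccc3)c2)s1)c1c(F)ccc(O)c1Cl`, 2.7 nM in this assay.

Compound 1 carries the highest number of the two; compound 2 gives the lower number, and that gap is beyond the scatter.

Compound 3 `O=C(c1ccc(-c2cccc(NS(=O)(=O)c3ccc(Cl)cc3)c2)s1)c1cc(F)c(F)c(O)c1F` is not yet measured. It differs from compound 1 by chloro in place of methyl on an aromatic carbon. For the measured compounds named here, no measured pair shows this exchange, so no step size is known from the series.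

For compound 3 the step of a 1.2-fold lower number from compound 1 to compound 3 (0.09 log units; within the scatter) is expected to be small, with no direction claimed beyond the scatter. Compound 3 is estimated at 8 nM, range 3 nM to 25 nM.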

Compound 3, half-maximal inhibitory concentration: 6.2 nM
Beside the measured number, compound 3's estimate is 1.3-fold (0.11 log units) above it; low and high end bracket the measured number.
By their numbers in this assay, from the lowest: compound 2; then compounds 3 and 1 (each within the scatter of the next).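

In this assay chloro in place of methyl on the 4-methylphenyl of the sulfonyl group gives a 1.6-fold lower number from compound 1 to compound 3 (0.20 log units; within the scatter), the first step readable in the series. This place, para to a large group, thus accepts chloro for methyl with no change beyond the scatter, on the evidence of this single pair. No measurement on hand bears on the reason for this result.

Other groups at this place, such as methoxy, an amine or a carboxylic acid, remain open. Also open, from the compounds shown here alone, is how plain hydrogen here compares with methyl and chloro on one unchanged core; compound 2 carries hydrogen here but differs elsewhere too.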